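The source may hold more compounds than are shown below. What is called first, only, known or untested is meant among the compounds shown, and "the series" means these compounds.

In a functional assay on HEK293 cells for agonist activity at probable G-protein coupled receptor 27 (Homo sapiens), read by a luciferase reporter and beta-arrestin recruitment, with a stated time of 10 min (a higher number here means that more compound is needed for the effect, a lower number that less compound is needed), compound 1 `O=C(Nc1ccc(S(=O)(=O)Nc2ccccc2)cc1)c1ccc(Cl)cc1F` gives 3980 nM, and compound 2 `O=C(Nc1ccc(S(=O)(=O)Nc2ccccc2)cc1)c1ccc(Cl)cc1Cl` gives 457 nM. The only measured movement so far is an 8.7-fold lower number from compound 1 to compound 2 (0.94 log units; beyond the scatter), and it leaves compound 2 with the lower of the two numbers, its nearest neighbour being compound 1 at the higher number already given. Compound 3 `Cc1cc(Br)ccc1C(=O)Nc1ccc(S(=O)(=O)Nc2ccccc2)cc1` differs from compound 2 in one place: 4-bromo-2-methylphenyl in place of 2,4-dichlorophenyl on a carbonyl carbon. The measured step bears on this only loosely, since it also concerns the ring on the carbonyl carbon, but it exchanged one halogen for another while keeping the rest of that ring the same, whereas compound 3 replaces both chlorines at once with a bromine and a methyl. For the measured compounds named here, no measured pair reports what a bromine or a methyl does on that ring. The expected step of a 1.3-fold higher number from compound 2 to compound 3 (0.12 log units; within the scatter) is therefore uncertain and set near no change beyond the scatter. Compound 3 is estimated at 600 nM, with a range from 150 nM to 3000 nM.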

Compound 3, half-maximal effective concentration: 851 nM
Beside the measured number, compound 3's estimate is 1.4-fold (0.15 log units) below it; low and high end bracket the measured number.
By their numbers in this assay, from the lowest: compounds 2 and 3 (each within the scatter of the next); then compound 1.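

In this assay, 4-bromo-2-methylphenyl on the carbonyl carbon stands level with 2,4-dichlorophenyl (a 1.9-fold higher number from compound 2 to compound 3 (0.27 log units; within the scatter)), which shows that two chlorines are not required for a number in this range. Against the 4-chloro-2-fluorophenyl of the first compound, the same group gives a clear step (a 4.7-fold lower number from compound 1 to compound 3 (0.67 log units; beyond the scatter)), so among the three compounds only compound 1 stands apart, and a second ring pattern now joins compound 2 on the lower side. Nothing at hand offers an explanation for either step.

The compounds shown do not separate the contribution of the bromine from that of the methyl, as the two enter together. Also open, going by these compounds, is how this position would read with a methoxy group, a trifluoromethyl group or an amine on the ring.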